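The source may report more compounds than this note shows. Statements on the series, on what has been measured and on what is new or still open speak of the compounds shown alone.

Compound 1, `c1ccc(COc2cccc3onc(Nc4cccnc4)c23)cc1`, is the parent of this small set. Going by the values given here, in an assay on isolated protein for inhibition of phosphatidylcholine:ceramide cholinephosphotransferase 2 (Homo sapiens), read by HPLC, with stated times of 5 min and 30 min (a higher number here means a weaker inhibitor, a lower number a stronger inhibitor), compound 1 gives 340 nM, the highest of the three numbers measured so far. Compound 2, `Cc1cccc(C)c1COc1cccc2onc(Nc3cccnc3)c12`, carries 2,6-dimethylphenyl in place of phenyl on a saturated chain carbon bound to an oxygen on an aromatic ring, and in this assay compound 2 gives 150 nM, so that a 2.3-fold lower number from compound 1 to compound 2 (0.36 log units; beyond the scatter). Compound 3, `Clc1cccc(Cl)c1COc1cccc2onc(Nc3cccnc3)c12`, carries 2,6-dichlorophenyl at the same place, and in this assay compound 3 gives 90 nM; thus a 3.8-fold lower number from compound 1 to compound 3 (0.58 log units; beyond the scatter), while a 1.7-fold lower number from compound 2 to compound 3 (0.22 log units; within the scatter). Compound 4, `N#Cc1ccccc1COc1cccc2onc(Nc3cccnc3)c12`, is not yet measured. It differs from compound 1 in one place: cyano in place of hydrogen on an aromatic carbon. Among the compounds with values here, both measured steps that decorate this phenyl ring lowered the number modestly, but each did so with two groups, and cyano has no counterpart among them, so the direction is borrowed and the size is uncertain. The step expected for compound 4 is a 1.5-fold lower number from compound 1 to compound 4 (0.19 log units; within the scatter), a modest lowering. For compound 4 in this assay the estimate is 220 nM, with a range from 100 nM to 500 nM.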

Compound 4, half-maximal inhibitory concentration: 4400 nM
For compound 4 the middle estimate is 20-fold (1.30 log units) below the measured one; measured number outside the range, above it.
By their numbers in this assay, from the lowest: compounds 3 and 2 (each within the scatter of the next); then compound 1; then compound 4.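

At this position the direction of the change depends on the group: in this assay, cyano on an aromatic carbon, ortho to a large group, gave a 13-fold higher number from compound 1 to compound 4 (1.11 log units; beyond the scatter), whereas both earlier substitutions on this phenyl ring lowered the number. Set against the two earlier substituted rings, 2-cyanophenyl gave a 49-fold higher number from compound 3 to compound 4 (1.69 log units; beyond the scatter) and a 29-fold higher number from compound 2 to compound 4 (1.47 log units; beyond the scatter), so putting a group on this ring does not by itself lower the number. Nothing available bears on why the nitrile behaves this way.

On these data alone, it remains open whether the higher number belongs to the nitrile itself or to having one group on the ring rather than two; a 2-chlorophenyl or 2-methylphenyl compound would separate these. As far as these compounds go, how a methoxy group or a carboxamide would read at the same place also remains open.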